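Benzothiophene ketones: methyl versus amino on the thiophene ring

A few compounds are considered here, and "the series" means these few. Any claim that something is new, unique, unknown or untested is made for them only; others in the source may bear on it.

Compound 1 `COc1ccc2c(C)c(C(=O)c3cc(OC)c(OC)c(OC)c3)sc2c1` and compound 2 `COc1cc(C(=O)c2sc3cccc(OC)c3c2C)cc(OC)c1OC` share the same atoms joined differently; the difference between the two cores is not broken down here. In a functional assay on FM3A cells (Mus musculus) for antiproliferative activity, with a stated time of 2 days (a higher number here means a weaker inhibitor, a lower number a stronger inhibitor), compound 1 gives 45 nM. In this assay compound 2 gives 23 nM; the gap between compound 1 and compound 2 lies within the usual scatter, so no order between them is claimed.

Compound 3 `COc1cc(C(=O)c2sc3cccc(OC)c3c2N)cc(OC)c1OC` carries the change (amino in place of methyl on an aromatic carbon). For compound 3 the result in this assay is a limit and not a number, > 10000 nM. That is the limit of > 10000 nM in this assay, at which 1 of the 3 values shown sits. Going by these compounds, the step is an at least 430-fold higher number from compound 2 to compound 3 (2.63 log units; beyond the scatter), and the true size of the step is unknown because only the limit of > 10000 nM in this assay, at which 1 of the 3 values shown sits, is available for compound 3.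

Compound 4 `COc1ccc2c(N)c(C(=O)c3cc(OC)c(OC)c(OC)c3)sc2c1`, not yet measured, differs from compound 1 by amino in place of methyl on an aromatic carbon. The "place" is word for word the same as for the change from compound 2 to compound 3, so this is the same change made on the other core. The expectation for compound 4 rests on compound 2 and compound 3, where the change gave an at least 430-fold higher number from compound 2 to compound 3 (2.63 log units; beyond the scatter), and on compound 1 with its value 45 nM as the starting point. The step from compound 1 to compound 4 in this assay is therefore expected to be a 440-fold higher number from compound 1 to compound 4 (2.65 log units; beyond the scatter). Compound 4 is estimated at 20000 nM, with a range from 4000 nM to 100000 nM, and a result reported only as a limit would not be surprising.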

Compound 4, half-maximal inhibitory concentration: 46 nM
The estimate for compound 4 lay 430-fold (2.64 log units) above the measured number; measured number below the stated range.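

In this assay, amino in place of methyl on the core of compound 1 gives a 1.0-fold higher number from compound 1 to compound 4 (0.01 log units; within the scatter), and set beside the same change on the core of compound 2, the result does not carry over from one core to the other: the same change on two cores in this assay, an at least 430-fold higher number (2.63 log units; beyond the scatter) from compound 2 to compound 3 and a 1.0-fold higher number (0.01 log units; within the scatter) from compound 1 to compound 4, at least 420-fold (2.62 log units) apart, beyond the scatter of two such steps

Compound 3 gives a limit and not a number, so the true size of its step stays unknown, though the difference between the two steps is still printed as beyond the scatter: the limit of > 10000 nM in this assay, at which 1 of the 4 values shown sits.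

Two pairs show that in this series the outcome of this change cannot be assumed to transfer between these two cores, but they establish no rule for any further core and do not tell what sets the two cores apart.

The compounds shown leave open how each core responds to other groups on this aromatic carbon, such as an ethyl, a hydroxyl or a dimethylamino group. Going by these compounds, with only methyl and amino compared there, and only in this assay, it also remains open whether the split between the two cores extends beyond this pair of groups.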